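Swapping the enone arm on a fused core: compound 4

The compounds below may be only part of what the source reports. "The series", "measured", "known", "first", "only" and "open" are said of these compounds alone.

Measured so far in a functional assay on MDA-MB-231 cells (Homo sapiens) for antiproliferative activity, read by MTT assay, with a stated time of 24 h; on this read-out higher numbers stand for weaker inhibition and lower numbers for stronger inhibition:
compound 1 `COc1ccc(C(=O)/C=C/c2cc(-c3ccc(OC)c(OC)c3)n3nc(-c4ccccc4)cc3n2)cc1` gives 13900 nM;
compound 2 `COc1ccc(/C=C/C(=O)c2cc(-c3cc(OC)c(OC)c(OC)c3)n3nc(-c4ccccc4)cc3n2)cc1OC` gives 14200 nM;
compound 3 `COc1ccc(-c2cc(/C=C/C(=O)c3ccccc3)nc3cc(-c4ccccc4)nn23)cc1` gives 9900 nM.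

Compound 1 holds the second highest of the three numbers; compound 2 is nearest, and compound 3 furthest, yet both lie within the scatter of compound 1, so the three compounds are not separated by this assay. Compound 4 `COc1ccc(-c2cc(C(=O)/C=C/c3ccc(Cl)cc3)nc3cc(-c4ccccc4)nn23)cc1OC` shares the core of compound 1 and differs from it in one place: (2-(4-chlorophenyl)ethenyl)carbonyl in place of 2-((4-methoxyphenyl)carbonyl)ethenyl on an aromatic carbon. Going by the values given here, no measured pair differs in only one place, so the data give no step against which to weigh this change. The step of a 1.2-fold lower number from compound 1 to compound 4 (0.06 log units; within the scatter) is therefore expected to be none beyond the scatter. Compound 4 is estimated to give 12000 nM, with a range from 4000 nM to 40000 nM.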

Compound 4, half-maximal inhibitory concentration: 23700 nM
For compound 4 the middle estimate is 2.0-fold (0.30 log units) below the measured one; the measured number falls inside the stated range.
By their numbers in this assay, from the lowest: compounds 3, 1, 2 and 4 (each within the scatter of the next, the first and the last beyond it).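

In this assay, going by these compounds alone, (2-(4-chlorophenyl)ethenyl)carbonyl in place of 2-((4-methoxyphenyl)carbonyl)ethenyl on this aromatic carbon gives a 1.7-fold higher number from compound 1 to compound 4 (0.23 log units; within the scatter), the first step that can be read on the shared core. This arm can therefore be exchanged as a whole without the assay separating the two compounds. No available evidence accounts for the size of this step. As far as these compounds go, how much the chlorine and the reversed order of carbonyl and ethenyl each contribute alone remains open. So does whether an amine or a carboxylic acid in place of the chlorine would give a step beyond the scatter.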